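Urea series, rice whole-organism read-out: compound 1 toward compound 4

The source may report more compounds than this note shows. Statements on the series, on what has been measured and on what is new or still open speak of the compounds shown alone.

Measured so far:
compound 1, `CC(C)c1cccc(NC(=O)N[C@H](C)c2ccccc2)c1`, 61%
compound 2, `CC(C)c1cccc(NC(=O)N[C@@H](C)c2ccccc2)c1`, 84%
compound 3, `CCOC(=O)c1ccc(NC(=O)N[C@H](C)c2ccccc2)cc1`, 100%

In an ADME assay on the whole organism with Oryza sativa as the target, tested at 1 uM (on this read-out higher numbers stand for a weaker effect at the one concentration tested and lower numbers for a stronger effect), compound 1 gives the lowest of the three numbers. For the measured compounds named here, its nearest neighbour is compound 2, which differs only in configuration as drawn; the step of a number 23 percentage points higher from compound 1 to compound 2 (beyond the scatter) is the only single-point step available and rests on (the fact that compounds 1 and 2 differ only in the configuration as drawn). Going by the values given here, compound 3, with a different substitution pattern on the anilide ring, gives the top number of the set and differs from compound 1 in more than one place, so no single step connects them.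

Compound 4, `C[C@@H](NC(=O)Nc1cccc(F)c1)c1ccccc1`, is not yet measured. It differs from compound 1 by fluoro in place of isopropyl on an aromatic carbon. Among the compounds with values here, no measured step changes this position, so the stereo step from compound 1 to compound 2 gives only a sense of the scale on which values in this set move, not its direction here. A modest shift upward is expected, given that compound 1 sits at the bottom of the range seen; the expected step is a number 14 percentage points higher from compound 1 to compound 4 (beyond the scatter). The value for compound 4 is estimated at 75%, within 50% to 100%.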

Compound 4, a percentage reported as activity, at one concentration (the size of the read-out at that concentration, not a potency): 95%
Estimate against measurement, compound 4: 20 percentage points below, and the stated range covers the measured number.
By their numbers in this assay, from the lowest: compound 1; then compound 2; then compounds 4 and 3 (each within the scatter of the next).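

In this assay, for the compounds shown here, this position on the aromatic ring is the first place where a change of substituent can be read on its own: a number 34 percentage points higher from compound 1 to compound 4 (beyond the scatter). The step is large and beyond the scatter, so the position is not indifferent to substitution, and the stronger effect seen with isopropyl in compound 1 does not carry over to fluoro in compound 4. Nothing at hand bears on the reason for this step.

With only isopropyl and fluoro shown at this place, it remains open whether the number moves steadily across substituents or whether isopropyl is a special case. A methyl, chloro, methoxy or amine group at the same carbon would help to separate these readings, as would the other drawn configuration of compound 4.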